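This account rests on a few compounds, and the source may have more. Where it says the series, first, only, none or still open, it means among the compounds named here.

Compound 1 `O[C@@H]1Cc2ccccc2N[C@H](c2ccccc2)C1`, compound 2 `O[C@@H]1Cc2cc(Cl)ccc2N[C@H](c2ccccc2)C1`, compound 3 `O[C@@H]1Cc2ccccc2N[C@H](c2ccc(Cl)cc2)C1`.

In an ADME assay on THP-1 cells (Homo sapiens) for cytotoxicity, read by MTT assay, with a stated time of 72 h (a lower number here means that less compound is tolerated, a higher number that more compound is tolerated), compound 1 gives > 300000 nM, which is a limit of the assay rather than a number (the limit of > 300000 nM in this assay, at which 1 of the 3 values shown sits). Compound 2 gives 188000 nM and compound 3 gives 114000 nM. Compound 3 stands within the scatter of compound 2, the only other number shown. Compound 4 `O[C@@H]1Cc2cc(Cl)ccc2N[C@H](c2ccc(Cl)cc2)C1` differs from compound 3 by chloro in place of hydrogen on an aromatic carbon. The same kind of change underlies the step of an at least 1.5-fold lower number from compound 1 to compound 2 (0.20 log units; that floor lies within the scatter) and the step of an at least 2.6-fold lower number from compound 1 to compound 3 (0.42 log units; beyond the scatter), both starting from a limit. A small to modest lowering is therefore expected for compound 4, as a 1.6-fold lower number from compound 3 to compound 4 (0.21 log units; within the scatter). Compound 4 is estimated at 70000 nM, with a range from 30000 nM to 160000 nM.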

Compound 4, half-maximal cytotoxic concentration: 49200 nM
For compound 4 the middle estimate is 1.4-fold (0.15 log units) above the measured one; measured number inside the range.
By their numbers in this assay, from the lowest: compound 4; then compounds 3 and 2 (each within the scatter of the next). At a limit, above all of these: compound 1.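

In this assay, chloro in place of hydrogen on the aromatic carbon of the fused system now gives a step between two measured numbers, a 2.3-fold lower number from compound 3 to compound 4 (0.36 log units; beyond the scatter). The chloro on the other ring does the same on the already chlorinated core, a 3.8-fold lower number from compound 2 to compound 4 (0.58 log units; beyond the scatter), so each chloro still lowers the number with the other present. Whether either step differs in size from its earlier counterpart, which starts from a limit, stays unsettled: the same change on two cores in this assay, an at least 1.5-fold lower number (0.20 log units; that floor lies within the scatter) from compound 1 to compound 2 and a 2.3-fold lower number (0.36 log units; beyond the scatter) from compound 3 to compound 4; the limit leaves it open whether they differ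

Going by these compounds, whether bromo, methoxy or an amine on the same carbon would lower the number as chloro does stays open.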